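Sulfonyl ring variation in a fluorinated pyrrole series

The source may report more compounds than this note shows. Statements on the series, on what has been measured and on what is new or still open speak of the compounds shown alone.

Compounds measured so far in a functional assay on the whole organism (strain Jcl:Sprague-Dawley) for inhibition, with Rattus norvegicus as the target, with stated times of 3 min and 3 h, at a dose of 1 mg/kg by the intravenous route; on this read-out lower numbers stand for less inhibition and higher numbers for more inhibition at the one dose given (going by the name of the read-out):
- compound 1 `CNCc1cn(S(=O)(=O)c2cccs2)c(-c2cccnc2F)c1F`: 98%
- compound 2 `CNCc1cn(S(=O)(=O)c2ncccc2C)c(-c2cccnc2F)c1F`: 54%
- compound 3 `CNCc1cn(S(=O)(=O)c2cccc(F)n2)c(-c2cccnc2F)c1F`: "not determined" (no result reported)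

Among the compounds with values here, the one step within the measured set runs between compound 1 and compound 2, where the group on the sulfonyl sulfur changes; it gives a number 44 percentage points lower from compound 1 to compound 2 (beyond the scatter), a large fall in this assay, well beyond the scatter of repeated measurements. Compound 3 carries a 6-fluoropyridin-2-yl group on the same sulfonyl sulfur, but no number exists for it in this assay, so its position relative to compound 1 and compound 2 cannot be stated.

Compound 4 `CNCc1cn(S(=O)(=O)c2ccc(F)cn2)c(-c2cccnc2F)c1F` differs from compound 3 only in that position: 5-fluoropyridin-2-yl in place of 6-fluoropyridin-2-yl on a sulfonyl sulfur
The change is a rearrangement of the same atoms within the 6-fluoropyridin-2-yl group. Within the data shown here, no measured step bears directly on it; the only step available, from compound 1 to compound 2, concerns a different exchange of the sulfonyl ring and shows only that this position can move the read-out strongly. With compound 3 lacking a value, no direction or size of step can be derived for compound 4, and the estimate rests on the spread seen between compound 1 and compound 2 alone.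

For compound 4 in this assay the expected inhibition is estimated at 65%, with a range from 25% to 95%.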

Compound 4, a percentage reported as inhibition, in the whole organism at one dose (the size of the read-out at that dose, not a potency) in the Rattus norvegicus assay: 87%
The estimate for compound 4 lay 22 percentage points below the measured number; the measured number falls inside the stated range.
By their numbers in the Rattus norvegicus assay, from the lowest: compound 2; then compound 4; then compound 1.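

In the Rattus norvegicus assay a pyridine ring on the sulfonyl sulfur can carry high inhibition, with a number 33 percentage points higher from compound 2 to compound 4 (beyond the scatter), while a number 11 percentage points lower from compound 1 to compound 4 (beyond the scatter), so the loss seen with 3-methylpyridin-2-yl does not extend to 5-fluoropyridin-2-yl. As far as these compounds go, compound 3 has no number in the Rattus norvegicus assay, so its steps there cannot be read, including the exchange of 6-fluoropyridin-2-yl for 5-fluoropyridin-2-yl, and the effect of that rearrangement on inhibition remains unknown. In a physicochemical assay for lipophilicity, read by HPLC, at pH 7.4 (a higher number here means a more lipophilic compound, a lower number a more polar compound), compound 3 gives 0.7 and compound 4 gives 0.42, with a number 0.28 log units lower from compound 3 to compound 4 (within the scatter), so this read-out does not separate the two fluoropyridine isomers.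

Nothing available gives a reason for the differences in inhibition across the sulfonyl groups. Still open, from the compounds shown here alone, is whether an unsubstituted pyridin-2-yl ring, or a pyridin-2-yl ring bearing an amine or a nitrile, would keep inhibition close to that of compound 4 or fall towards that of compound 2.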